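A few compounds are considered here, and "the series" means these few. Any claim that something is new, unique, unknown or untested is made for them only; others in the source may bear on it.

Measured so far in an assay on CHO cells for displacement of a labelled ligand from histamine receptor H3 (Macaca mulatta); a higher number here means a weaker inhibitor, a lower number a stronger inhibitor:

Compound 1, `Cc1cc(N2CCC(N3CCCC3C)C2)ccc1NC(=O)C1CCCO1`: in this assay compound 1 gives 7.34 nM.
Compound 2, `Cc1cc(NC(=O)C2CC2)ccc1N1CCC(N2CCCC2C)C1`: in this assay compound 2 gives 17.7 nM.
Compound 3, `Cc1cc(N2CCC(N3CCCC3C)C2)ccc1NC(=O)C1CC1`: in this assay compound 3 gives 9.6 nM.

Compound 3 and compound 1 differ in one place: oxolan-2-yl in place of cyclopropyl on a carbonyl carbon. The step that went with this change was a 1.3-fold lower number from compound 3 to compound 1 (0.12 log units; within the scatter), so the two compounds cannot be told apart on this assay.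

Compound 2 has the same atoms as compound 3, joined differently; the difference between the two cores is not broken down here. Against compound 3, compound 2 is within the scatter. Against compound 1, compound 2 stands beyond the scatter, the number for compound 2 being the higher one.

Compound 4, `Cc1cc(NC(=O)C2CCCO2)ccc1N1CCC(N2CCCC2C)C1`, is not yet measured in this assay. It is made from compound 2 by the same change seen from compound 3 to compound 1: oxolan-2-yl in place of cyclopropyl on a carbonyl carbon. This change has been seen only once among these compounds, on the core of compound 3, and there it made no step beyond the scatter. Within the data shown here, the expectation is that on the core of compound 2 it behaves in the same way, and the step from compound 2 to compound 4 is therefore estimated as a 1.3-fold lower number from compound 2 to compound 4 (0.10 log units; within the scatter), resting on the single earlier instance a 1.3-fold lower number from compound 3 to compound 1 (0.12 log units; within the scatter). For compound 4 the expected value in this assay is 14 nM, with an estimated range from 6 nM to 32 nM.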

Compound 4, inhibition constant: 17 nM
For compound 4 the middle estimate is 1.2-fold (0.08 log units) below the measured one, and the stated range covers the measured number.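

In this assay, oxolan-2-yl in place of cyclopropyl on a carbonyl carbon gives a 1.0-fold lower number from compound 2 to compound 4 (0.02 log units; within the scatter), so the two compounds cannot be told apart in this assay. Carried from one core to the other, the change reads the same on both: the same change on two cores in this assay, a 1.3-fold lower number (0.12 log units; within the scatter) from compound 3 to compound 1 and a 1.0-fold lower number (0.02 log units; within the scatter) from compound 2 to compound 4, 1.3-fold (0.10 log units) apart, within the scatter of two such steps

Among these compounds, this shows that, on these two cores, the exchange of cyclopropyl for oxolan-2-yl leaves the number within the scatter, and that the added oxygen-bearing ring brings no step that can be read in this assay on either core, but it does not show that a step of real size would carry over in the same way, since neither step here stands beyond the scatter, nor does it say anything about a third core or about any other change on the carbonyl carbon.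

The compounds shown hold only cyclopropyl and oxolan-2-yl at this place, so it stays open whether a group such as an amine, a carboxylic acid or a longer chain on the carbonyl carbon would give a step beyond the scatter. On these data alone, it also stays open whether such a step, if one appeared, would match on the core of compound 1 and the core of compound 2.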